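This account rests on a few compounds, and the source may have more. Where it says the series, first, only, none or still open, it means among the compounds named here.

Two members of the series carry numbers in an ADME assay on microsomes from liver (Homo sapiens) for metabolic stability, tested at 2.5 uM; on this read-out higher numbers stand for fast clearance and lower numbers for slow clearance. Compound 1 `COc1ccc(S(=O)(=O)c2cnc3c(F)cccc3c2-c2cccc(OC)c2)cc1` gives 2.87 mL/min, and compound 2 `COc1cccc(-c2c(S(=O)(=O)c3cc(F)cc(F)c3)cnc3c(F)cccc23)c1` gives 2.76 mL/min. Compound 2 holds the lowest of the two numbers, with compound 1 as its nearest neighbour, and the step of a 1.0-fold lower number from compound 1 to compound 2 (0.02 log units; within the scatter) lies within the scatter. Compound 3 `COc1cccc(-c2c(S(=O)(=O)c3ccc(F)cc3)cnc3c(F)cccc23)c1` has no number in this assay yet. It differs from compound 2 in one place, on a sulfonyl sulfur: 4-fluorophenyl in place of 3,5-difluorophenyl on a sulfonyl sulfur. For the measured compounds named here, the only measured step that bears on this change is the one at the same place, a 1.0-fold lower number from compound 1 to compound 2 (0.02 log units; within the scatter), which stayed within the scatter. On that basis no step beyond the scatter is expected in this assay from compound 2 to compound 3, and the expected step is a 1.0-fold higher number from compound 2 to compound 3 (0.01 log units; within the scatter). Compound 3 is therefore expected to give 2.8 mL/min, within a range from 1.5 mL/min to 5.5 mL/min.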

Compound 3, intrinsic clearance in a liver preparation (reported as CLH), per the amount of preparation that the assay uses: 2.23 mL/min
For compound 3 the middle estimate is 1.3-fold (0.10 log units) above the measured one, and the stated range covers the measured number.
By their numbers in this assay, from the lowest: compounds 3, 2 and 1 (each within the scatter of the next).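

In this assay, 4-fluorophenyl in place of 3,5-difluorophenyl on the sulfonyl sulfur gives a 1.2-fold lower number from compound 2 to compound 3 (0.09 log units; within the scatter), so the count of fluorines on this phenyl group, at the two patterns shown, does not move the number beyond the scatter. The comparison with the methoxy-bearing group, fluoro in place of methoxy on an aromatic carbon, gives a 1.3-fold lower number from compound 1 to compound 3 (0.11 log units; within the scatter) and likewise stays within the scatter. All three substituted phenyl groups on the sulfonyl sulfur therefore stand within the scatter of one another, and no available information bears on the small differences among them.

On these data alone, whether a different kind of group on this phenyl ring, such as an amine or a carboxylic acid, would give a step beyond the scatter stays open. As far as these compounds go, what a change elsewhere on the shared core would do also stays open.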